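Benzamide in Place of Pyridine Amide on an Inactive Core

This account rests on a few compounds, and the source may have more. Where it says the series, first, only, none or still open, it means among the compounds named here.

Measured compounds:
compound 1 `O=C(Nc1ccc(Cl)c(-c2nnc3c(Cl)cccn23)c1)c1ccccn1` — in a functional assay on A549 cells (Homo sapiens) for antiproliferative activity, read by MTT assay, with a stated time of 72 h (a higher number here means a weaker inhibitor, a lower number a stronger inhibitor), compound 1 gives only a limit of the assay, > 100000 nM
compound 2 `Cc1nc(C(=O)Nc2ccc(Cl)c(-c3nnc4c(Cl)cccn34)c2)cs1` — in this assay compound 2 gives only a limit, > 100000 nM
compound 3 `O=C(Nc1ccc(Cl)c(-c2nnc3c(Cl)cccn23)c1)c1cccnc1` — in this assay compound 3 gives only a limit, > 100000 nM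

Compound 1 therefore has no read number, only a limit. Its steps to its two neighbours, a step that the two limits leave unreadable from compound 1 to compound 2 and a step that the two limits leave unreadable from compound 1 to compound 3, stay without size, because of the limit of > 100000 nM in this assay, at which 3 of the 3 values shown sit.

Compound 4 `O=C(Nc1ccc(Cl)c(-c2nnc3c(Cl)cccn23)c1)c1c(F)cccc1Cl` changes the amide partner: 2-chloro-6-fluorophenyl in place of pyridin-2-yl on a carbonyl carbon. Going by the values given here, no measured step with a readable size bears on this change, so no direction can be drawn from the data. Compound 4 is expected again to sit at or near the assay limit, estimated at 150000 nM (range 30000 nM to 500000 nM). The implied step that the limit leaves unreadable from compound 1 to compound 4 is likewise only an expectation.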

Compound 4, half-maximal inhibitory concentration: 72300 nM
Beside the measured number, compound 4's estimate is 2.1-fold (0.32 log units) above it, within the range that was stated.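

In this assay compound 4 gives 72300 nM, so 2-chloro-6-fluorophenyl on the carbonyl carbon is the only amide partner shown with a read number. Replacing pyridin-2-yl gives an at least 1.3-fold lower number from compound 1 to compound 4 (0.14 log units; that floor lies within the scatter), replacing pyridin-3-yl gives an at least 1.3-fold lower number from compound 3 to compound 4 (0.14 log units; that floor lies within the scatter), and replacing 2-methyl-1,3-thiazol-4-yl gives an at least 1.3-fold lower number from compound 2 to compound 4 (0.14 log units; that floor lies within the scatter). Each step is only a floor, so the true size of these changes stays unknown, since the other compounds give only a limit: the limit of > 100000 nM in this assay, at which 3 of the 4 values shown sit.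

From the compounds shown here alone, whether the chlorine, the fluorine or the carbon-only ring matters stays open. So does the outcome with an unsubstituted phenyl or with an amine on that ring.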